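This account rests on a few compounds, and the source may have more. Where it says the series, first, only, none or still open, it means among the compounds named here.

Measured compounds in the series:

- compound 1, `CN(C)c1ccc(/C=N\NC(=S)NC2CCCCC2)cc1` — 51100 nM
- compound 2, `COc1ccc(/C=N\NC(=S)NC2CCCCC2)cc1OC` — 99200 nM

Both numbers come from a functional assay on MCF7 cells (Homo sapiens) for inhibition, read by WST assay, with a stated time of 48 h; on this read-out lower numbers stand for stronger inhibition and higher numbers for weaker inhibition. Compound 1 and compound 2 lie within the scatter of each other on this read-out, so no separation between the two can be claimed; the whole measured series sits at high concentrations.

The next compound, compound 3, `CCOc1ccc(/C=N\NC(=S)NC2CCCCC2)cc1`, has not yet been measured in this assay. It differs from compound 1 in one place: ethoxy in place of dimethylamino on an aromatic carbon. Going by the values given here, nothing measured so far isolates this exchange, and the only other measured compound, compound 2, carries two methoxy groups rather than a single ethoxy, so it gives only a loose anchor.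

With two measured compounds that cannot be told apart, the step from compound 1 to compound 3 is expected to stay within the scatter, in either direction, a 1.4-fold higher number from compound 1 to compound 3 (0.14 log units; within the scatter). Compound 3 is therefore estimated at 70000 nM in this assay, with a range from 25000 nM to 200000 nM, the upper end allowing for the possibility that a number near the top of the tested range is returned.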

Compound 3, half-maximal inhibitory concentration: 166000 nM
Beside the measured number, compound 3's estimate is 2.4-fold (0.38 log units) below it; the measured number falls inside the stated range.
By their numbers in this assay, from the lowest: compounds 1, 2 and 3 (each within the scatter of the next, the first and the last beyond it).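

Going by these compounds alone, on this assay, the position on the aromatic carbon para to a large group gives the first single exchange that can be read: ethoxy in place of dimethylamino gives a 3.2-fold higher number from compound 1 to compound 3 (0.51 log units; beyond the scatter), a modest step but one beyond the scatter, so this position is not indifferent to the change. The two groups match in every count available, namely heavy atoms, rings, hydrogen-bond donors, hydrogen-bond acceptors and net charge, and they differ in that nitrogen leaves and oxygen enters, so those counts do not separate compound 1 from compound 3. No measurement at hand accounts for the step, which stands here as an observation only.

Still open, from the compounds shown here alone, is where other groups on the same aromatic carbon would fall relative to compound 1 and compound 3, for example a primary amine, a carboxylic acid or a longer alkoxy chain such as butoxy. Also open, going by these compounds, is whether the same exchange would give a step of similar size if the cyclohexyl group on the thiourea side were replaced by a phenyl group.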